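This account rests on a few compounds, and the source may have more. Where it says the series, first, only, none or still open, it means among the compounds named here.

Measured so far:
- compound 1 `Cc1cccc(NC(=O)c2cc(-c3ccccc3)n(C)n2)n1`: 95 nM
- compound 2 `Cc1cccc(NC(=O)c2nn(C)c(-c3ccccc3)c2C)n1`: 4.4 nM

In a functional assay on HEK293 cells for negative allosteric modulation of metabotropic glutamate receptor 5 (Homo sapiens), read by FLIPR and calcium flux (a lower number here means a stronger inhibitor, a higher number a weaker inhibitor), compound 1 gives 95 nM, and compound 2 gives 4.4 nM. Within the data shown here, the one step measured between them, a 22-fold lower number from compound 1 to compound 2 (1.33 log units; beyond the scatter), is the single piece of evidence available. Compound 2 therefore stands at the lowest number of the two, with compound 1 well beyond the scatter from it.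

Compound 3 `Cc1cccc(NC(=O)c2nn(C)c(OC3CCCCC3)c2C)n1` is not yet measured. It differs from compound 2 by one change, (cyclohexyloxy in place of phenyl on an aromatic carbon). Among the measured compounds shown here, no measured step bears on this exchange: the only step seen, from compound 1 to compound 2, concerns a methyl group on the five-membered ring, and the group that is swapped here is left untouched in both measured compounds. What happens when a large group on the ring is replaced by a different large group carrying an oxygen is therefore unknown from these data.

With nothing to anchor the direction, the estimate for compound 3 is placed somewhat weaker than compound 2, at 30 nM with a range from 5 nM to 200 nM, which means an expected step of a 6.8-fold higher number from compound 2 to compound 3 (0.83 log units; beyond the scatter).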

Compound 3, half-maximal inhibitory concentration: 92 nM
Estimate against measurement, compound 3: 3.1-fold (0.49 log units) below; the measured number falls inside the stated range.
By their numbers in this assay, from the lowest: compound 2; then compounds 3 and 1 (each within the scatter of the next).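

In this assay, the phenyl of compound 2 cannot be exchanged freely at this place on the five-membered ring: with cyclohexyloxy in its place and the rest of the structure unchanged, the result is a 21-fold higher number from compound 2 to compound 3 (1.32 log units; beyond the scatter). This makes the position the second place shown to matter, alongside the methyl exchange in a 22-fold lower number from compound 1 to compound 2 (1.33 log units; beyond the scatter), although that step lowered the number and this one raises it, so a change at either place can shift the reading by a large margin. The compounds shown offer no measurement that accounts for the loss seen with cyclohexyloxy.

This single exchange replaces an aromatic ring with a non-aromatic one and also brings in an oxygen, and compounds 2 and 3 cannot separate those two changes. Phenoxy, which keeps the aromatic ring and adds the oxygen, and cyclohexyl, which has the non-aromatic ring without the oxygen, would each change only one of these features, so whether either stays close to compound 2 remains open.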